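Chain extension on a phenyl-bearing cyanoguanidine analogue

The source may hold more compounds than are shown below. What is called first, only, known or untested is meant among the compounds shown, and "the series" means these compounds.

The series shares one core and differs at the saturated ring carbon and in the chain to the chlorophenyl ether. Compound 1 `CC1C(=O)N(CCCCCCOc2ccc(Cl)cc2)/C(=N\C#N)N1c1ccncc1` gives 382 nM in a functional assay on HA22T cells for cytotoxicity against HA22T cell line (Homo sapiens); on this read-out higher numbers stand for weaker inhibition and lower numbers for stronger inhibition. Within the data shown here, compound 2 `CCC1C(=O)N(CCCCCCOc2ccc(Cl)cc2)/C(=N\C#N)N1c1ccncc1` gives 5130 nM; the only single-point step recorded, a 13-fold higher number from compound 1 to compound 2 (1.13 log units; beyond the scatter), is large. Compound 3 `N#C/N=C1\N(CCCCCOc2ccc(Cl)cc2)C(=O)C(c2ccccc2)N1c1ccncc1` gives 3590 nM, which places it second highest of the three numbers: its gap to compound 2 lies within the scatter, while its gap to compound 1 lies beyond it. Compound 4 `N#C/N=C1\N(CCCCCCOc2ccc(Cl)cc2)C(=O)C(c2ccccc2)N1c1ccncc1` has not yet been measured. It differs from compound 3 by (4-chlorophenoxy)methyl in place of 4-chlorophenoxy on a saturated chain carbon, five bonds along the chain from an amide-type nitrogen in a ring. Among the measured compounds shown here, no measured step addresses a change of this kind; the step from compound 1 to compound 2 concerns the ring substituent, not the chain, so it does not bear on this change directly. Compound 4 is therefore expected to lie close to compound 3, with the step of a 1.2-fold lower number from compound 3 to compound 4 (0.08 log units; within the scatter) expected to fall within the scatter. Compound 4 is estimated at 3000 nM, within the range 700 nM to 13000 nM.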

Compound 4, half-maximal inhibitory concentration: 526 nM
For compound 4 the middle estimate is 5.7-fold (0.76 log units) above the measured one; measured number outside the range, below it.
By their numbers in this assay, from the lowest: compounds 1 and 4 (each within the scatter of the next); then compounds 3 and 2 (each within the scatter of the next).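

In this assay, the chain proves to be a sensitive place: with phenyl held on the saturated ring carbon, (4-chlorophenoxy)methyl in place of 4-chlorophenoxy gives a change beyond the scatter (a 6.8-fold lower number from compound 3 to compound 4 (0.83 log units; beyond the scatter)). With the chain of compound 4 held fixed, the ring carbon tolerates phenyl as well as methyl (a 1.4-fold higher number from compound 1 to compound 4 (0.14 log units; within the scatter)), while phenyl in place of ethyl gives a clear change (a 9.8-fold lower number from compound 2 to compound 4 (0.99 log units; beyond the scatter)), so among these three compounds only the ethyl compound 2 stands apart. No available evidence accounts for these steps.

From the compounds shown here alone, it remains open whether the same chain change acts alike with methyl or ethyl on the saturated ring carbon, and whether a longer chain would continue in the same direction. Going by these compounds, the effect of a benzyl group or an amine on that ring carbon also remains open.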